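Compound 3: methoxy to hydroxy

The source may report more compounds than this note shows. Statements on the series, on what has been measured and on what is new or still open speak of the compounds shown alone.

In a functional assay on MCF7 cells (Homo sapiens) for cytotoxicity, read by MTT assay, with a stated time of 72 h (a higher number here means a weaker inhibitor, a lower number a stronger inhibitor), compound 1 (`COc1cccc(/C=C2\CCC/C(=C\c3cccc(O)c3)C2=O)c1OC`) gives 8800 nM and compound 2 (`COc1ccc(/C=C2\CCC/C(=C\c3cccc(OC)c3OC)C2=O)cc1OC`) gives 6500 nM as well, so compound 2 stands within the scatter of compound 1. Compound 3 (`COc1cc(/C=C2\CCC/C(=C\c3cccc(OC)c3OC)C2=O)ccc1O`) has hydrogen in place of methyl on an oxygen on an aromatic ring relative to compound 2 (hydrogen in place of methyl on an oxygen on an aromatic ring). Among the measured compounds shown here, no measured pair isolates this methoxy to hydroxy change, but compound 1 already carries a hydroxy and sits at 8800 nM in this range. The expected 1.3-fold lower number from compound 2 to compound 3 (0.11 log units; within the scatter) stays within the scatter, with no direction expected beyond it. For compound 3 the estimated value is 5000 nM with an expected range of 2000 nM to 12000 nM here.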

Compound 3, half-maximal inhibitory concentration: 11600 nM
Estimate against measurement, compound 3: 2.3-fold (0.37 log units) below; the range from low to high includes it.
By their numbers in this assay, from the lowest: compounds 2, 1 and 3 (each within the scatter of the next).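

In this assay, hydrogen in place of methyl on an oxygen on an aromatic ring gives a 1.8-fold higher number from compound 2 to compound 3 (0.25 log units; within the scatter) in a pair differing in this one place, so methoxy and hydroxy are not told apart here. With 4-hydroxy-3-methoxyphenyl in place of 3-hydroxyphenyl, a 1.3-fold higher number from compound 1 to compound 3 (0.12 log units; within the scatter) also leaves the two compounds together. No available evidence bears on this result.

From the compounds shown here alone, an amine in place of the hydroxy, or a longer chain than methyl on that oxygen, remains open. So does whether any change at this place moves the number beyond the scatter.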